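The compounds below may be only part of what the source reports. "The series", "measured", "known", "first", "only" and "open" are said of these compounds alone.

The three measured compounds and their numbers in a functional assay on the whole organism (artery, strain albino) with Rattus norvegicus as the target, with a stated time of 360 min, at a dose of 10 mg/kg by the oral route; on this read-out higher numbers stand for more inhibition at the one dose given (going by the name of the read-out) and lower numbers for less inhibition:
Compound 1, `COc1ccc(C2N=C(SCc3ccccc3)NC(C)=C2C(=O)Nc2ccc(F)cc2)cc1OC`, gives 3.6%.
Compound 2, `COc1ccc(C2N=C(SCc3ccc(Cl)cc3)NC(C)=C2C(=O)Nc2ccc(F)cc2)cc1OC`, gives 37.1%.
Compound 3, `CC1=C(C(=O)Nc2ccc(Br)cc2)C(c2ccc(Cl)cc2Cl)N=C(SCc2ccccc2)N1`, gives 24.2%.

Compound 3 stands second of the three numbers in this assay: it sits beyond the scatter below compound 2 and beyond the scatter above compound 1.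

Compound 4, `CC1=C(C(=O)Nc2ccc(Br)cc2)C(c2ccc(Cl)cc2Cl)N=C(SCc2ccc(Cl)cc2)N1`, has not yet been measured. It differs from compound 3 in one place: chloro in place of hydrogen on an aromatic carbon. Read one bond further out, the change is benzylsulfanyl to (4-chlorobenzyl)sulfanyl.

Going by the values given here, one measured step bears directly on this change. Between compound 1 and compound 2 the same exchange was made on the same benzylsulfanyl group, and it gave a number 33.5 percentage points higher from compound 1 to compound 2 (beyond the scatter). Among the compounds with values here, that single step is the only guide; it was made on a core carrying different aryl groups, so its size may not carry over unchanged. Still, it points to a rise in this assay beyond the scatter for compound 4.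

The step from compound 3 to compound 4 is therefore expected to read a number 23.8 percentage points higher from compound 3 to compound 4 (beyond the scatter). Compound 4 is estimated at 48%, with a range from 22% to 72%.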

Compound 4, a percentage reported as inhibition, in the whole organism at one dose (the size of the read-out at that dose, not a potency): 39.7%
Compound 4: the middle estimate sits 8.3 percentage points above what was measured; low and high end bracket the measured number.
By their numbers in this assay, from the lowest: compound 1; then compound 3; then compounds 2 and 4 (each within the scatter of the next).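

The exchange of benzylsulfanyl for (4-chlorobenzyl)sulfanyl gave a number 15.5 percentage points higher from compound 3 to compound 4 (beyond the scatter) in this assay, so the rise with chloro on this aromatic carbon is no longer confined to a single pair of compounds. The direction of the change held on both cores, but its size did not: the same change on two cores in this assay, a number 33.5 percentage points higher (beyond the scatter) from compound 1 to compound 2 and a number 15.5 percentage points higher (beyond the scatter) from compound 3 to compound 4, 18 percentage points apart, beyond the scatter of two such steps The two cores differ in more than one place, so these two pairs cannot tell which of their other groups goes with the larger step.

Only hydrogen and chloro appear at this position, which leaves open whether fluoro, methoxy, trifluoromethyl or a carboxylic acid in the place of the chloro would also raise the number, and by how much on each core. Also open, going by these compounds, is how these steps would look at other doses or times, since this read-out gives the size of the inhibition at one dose and is not a potency.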